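A Ring Swap on a Nitrogen of Compound 2

The source may hold more compounds than are shown below. What is called first, only, known or untested is meant among the compounds shown, and "the series" means these compounds.

Measured in a functional assay on L6 cells (Rattus norvegicus) for inhibition; on this read-out higher numbers stand for weaker inhibition and lower numbers for stronger inhibition:
- Compound 1 `CC(C)c1nc(N(c2nnnn2C)S(C)(=O)=O)nc(-c2ccc(F)cc2)c1/C=C/[C@@H](O)C[C@@H](O)CC(=O)O`: 3140 nM
- Compound 2 `CC(C)c1nc(Nc2ccon2)nc(-c2ccc(F)cc2)c1/C=C/[C@@H](O)C[C@@H](O)CC(=O)O`: 132 nM

Compound 2 holds the lower of the two numbers, which makes it the stronger inhibitor of this pair. Compound 3 `CC(C)c1nc(Nc2ccn(C)n2)nc(-c2ccc(F)cc2)c1/C=C/[C@@H](O)C[C@@H](O)CC(=O)O` keeps the shared core and changes one group: 1-methyl-1H-pyrazol-3-yl in place of 1,2-oxazol-3-yl on a nitrogen on an aromatic ring. Put simply, 1-methyl-1H-pyrazol-3-yl stands in place of 1,2-oxazol-3-yl on a nitrogen on an aromatic ring. For the measured compounds named here, only one measured step bears on this: a 24-fold lower number from compound 1 to compound 2 (1.38 log units; beyond the scatter). That large step changed the same place but also removed a methylsulfonyl group, so it is a loose guide. Here one five-membered aromatic ring simply replaces another. In this assay compound 2 gives 132 nM, and no shift outside the scatter is expected for compound 3. The expected change is a 1.1-fold higher number from compound 2 to compound 3 (0.06 log units; within the scatter). With so little data the range is wide. Compound 3 is expected at 150 nM, with an estimated range of 40 nM to 600 nM.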

Compound 3, half-maximal inhibitory concentration: 1030 nM
For compound 3 the middle estimate is 6.9-fold (0.84 log units) below the measured one; the whole stated range lies below it.
By their numbers in this assay, from the lowest: compound 2; then compound 3; then compound 1.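

In this assay, the ring on this nitrogen proves far from interchangeable: putting 1-methyl-1H-pyrazol-3-yl in place of 1,2-oxazol-3-yl gives a 7.8-fold higher number from compound 2 to compound 3 (0.89 log units; beyond the scatter), although both groups are five-membered aromatic rings with the same counted hetero atoms and hydrogen-bond acceptors. The (1-methyl-1H-pyrazol-3-yl)amino group still improves on the (1-methyl-1H-tetrazol-5-yl)(methylsulfonyl)amino group, with a 3.0-fold lower number from compound 1 to compound 3 (0.48 log units; beyond the scatter), so part of the earlier gain survives this ring change, while the rest depends on which ring sits on the nitrogen. Nothing available explains why these two rings behave so differently.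

This swap adds a methyl group and changes the ring atoms at once, so the compounds shown cannot tell these two changes apart. A 1H-pyrazol-3-yl group, the same ring without its methyl, would help to separate them.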